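Hydrogen for trifluoromethyl on the fused ring of compound 1

The compounds below may be only part of what the source reports. "The series", "measured", "known", "first", "only" and "open" are said of these compounds alone.

Measured so far:
- compound 1 `CNC(=O)c1sc(N2CC3CC2(CNC(=O)c2c[nH]c4ncc(C(F)(F)F)cc24)C3)nc1C(F)(F)F`: in an ADME assay on cells (Hepatocyte, Rattus norvegicus) for metabolic stability (a lower number here means slower removal, a higher number faster removal of the compound), compound 1 gives 78 uL/min
- compound 2 `C[C@@H]1CN(c2cnc(Nc3cc(F)c(OCC4CC4)c(F)c3)nc2NC2CCOCC2)CCN1`: compound 2 gives < 2.4 uL/min
- compound 3 `CS(=O)(=O)c1cnc(Nc2ccc(O)cc2)nc1NCc1ccccc1`: compound 3 gives 32 uL/min

Compound 1 stands highest of the two numbers in this assay; compound 3 sits lower, a gap beyond the usual scatter. The value of compound 2 is a limit of the assay rather than a number (the limit of < 2.4 uL/min in this assay, at which 1 of the 3 values shown sits). Compound 4 `CNC(=O)c1sc(N2CC3CC2(CNC(=O)c2c[nH]c4ncccc24)C3)nc1C(F)(F)F` differs from compound 1 by hydrogen in place of trifluoromethyl on an aromatic carbon. Within the data shown here, no measured pair shows this change, so no step size is on record for it. The step is expected to be small, at most a modest move upward, as a 1.3-fold higher number from compound 1 to compound 4 (0.11 log units; within the scatter). Compound 4 is estimated at 100 uL/min, with a range from 40 uL/min to 250 uL/min.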

Compound 4, intrinsic clearance in a liver preparation (reported as CLH), per the amount of preparation that the assay uses: 33 uL/min
Compound 4: the middle estimate sits 3.0-fold (0.48 log units) above what was measured, and the stated range ends above it.
By their numbers in this assay, from the lowest: compounds 3 and 4 (each within the scatter of the next); then compound 1. At a limit, below all of these: compound 2.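

Hydrogen in place of trifluoromethyl on this aromatic carbon gives a 2.4-fold lower number from compound 1 to compound 4 (0.37 log units; beyond the scatter) in this assay, the first step in the series between compounds that differ in one place. At this position, trifluoromethyl therefore goes with faster removal than hydrogen, though this rests on a single pair sharing one core. Among these compounds, nothing measured so far gives a cause for this step.

As far as these compounds go, it remains open whether a chlorine atom or a nitrile on the same carbon would stay close to hydrogen or to trifluoromethyl. From the compounds shown here alone, it also remains open whether the same change would give a similar step on a different core.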